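Adding One Fluorine to a Short Fluorinated Alcohol

The source may hold more compounds than are shown below. What is called first, only, known or untested is meant among the compounds shown, and "the series" means these compounds.

Compound 1 `OCCCC(F)CF`: 0.11
Compound 2 `OCCC(F)(F)C(F)F`: 0.66
Compound 3 `OCCC(F)CF`: -0.12

In a physicochemical assay for lipophilicity, read by NMR (a higher number here means a more lipophilic compound, a lower number a more polar compound), compound 3 gives the lowest of the three numbers; compound 1 sits within the scatter of it, while compound 2 lies well beyond it. Among the compounds with values here, the only measured step, a number 0.23 log units lower from compound 1 to compound 3 (within the scatter), concerns a different kind of change and says little about adding fluorine. Compound 4 `OCCC(F)C(F)F` differs from compound 3 by fluoro in place of hydrogen on a saturated chain carbon bound to a fluorine atom and a saturated chain carbon. Within the data shown here, with no directly comparable step, the expectation rests on where compound 2 and compound 3 stand: their values suggest a move upward, and compound 4 is expected to show a step of a number 0.37 log units higher from compound 3 to compound 4 (beyond the scatter) in this assay. Compound 4 is therefore estimated at 0.25, between -0.05 and 0.55.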

Compound 4, partition coefficient: 0.29
Compound 4: middle estimate off by 0.04 log units, on the low side, and the stated range covers the measured number.
By their numbers in this assay, from the lowest: compounds 3, 1 and 4 (each within the scatter of the next, the first and the last beyond it); then compound 2.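

In this assay, within the data shown here, the step of a number 0.41 log units higher from compound 3 to compound 4 (beyond the scatter) is the first measured effect of fluoro in place of hydrogen on a saturated chain carbon bound to a fluorine atom and a saturated chain carbon, and it lies beyond the scatter. Hydrogen in place of fluoro on a saturated chain carbon bound to a fluorine atom and two saturated chain carbons gives a number 0.37 log units lower from compound 2 to compound 4 (beyond the scatter), also beyond the scatter. Nothing here gives a measured reason for either step. From the compounds shown here alone, whether fluoro in place of hydrogen moves the number the same way on a longer chain remains open, as does its effect with an amine or a carboxylic acid in place of the hydroxy.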